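The compounds below may be only part of what the source reports. "The series", "measured", "known", "first", "only" and "open" are said of these compounds alone.

Within the data shown here, compound 1 `CC1CCN(C(=O)CN(C)C(=O)c2ccc(S(C)(=O)=O)c([N+](=O)[O-])c2)CC1` is one of three compounds tested so far in an assay on isolated protein for inhibition of vitamin D3 receptor (Homo sapiens), read by fluorescence polarization; on this read-out higher numbers stand for weaker inhibition and lower numbers for stronger inhibition. In this assay compound 1 gives > 60000 nM, which is a limit of the assay rather than a number. Compound 2 `CN(Cc1cccc(F)c1)C(=O)CNC(=O)c1ccc(S(C)(=O)=O)c([N+](=O)[O-])c1` gives > 60000 nM, again a limit. Compound 3 `CS(=O)(=O)c1ccc(C(=O)NCCCC(=O)N2Cc3ccccc3C2)cc1[N+](=O)[O-]` gives > 60000 nM, also a limit. Every value shown therefore sits at the limit of > 60000 nM in this assay, at which 3 of the 3 values shown sit, and compound 1 stands with the others at that limit, with nothing to set any of the three apart. Compound 4 `CCCN(C(=O)CN(C)C(=O)c1ccc(S(C)(=O)=O)c([N+](=O)[O-])c1)c1ccccc1` differs from compound 1 in one place (phenyl(propyl)amino in place of 4-methylpiperidin-1-yl on a carbonyl carbon). Among the measured compounds shown here, no step between measured compounds is available, so there is no measured guide to the size of the change. The expectation is that the step from compound 1 to compound 4 is a step that the limit leaves unreadable from compound 1 to compound 4, none beyond the usual scatter. Compound 4 is accordingly expected to give about 80000 nM, most likely reported as a limit again, within a range from 30000 nM to 300000 nM.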

Compound 4, half-maximal inhibitory concentration: > 60000 nM
Compound 4: no number, only a limit; the forecaster's own chance of this, stated with the estimate: 85%; the middle value lies beyond the limit too.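

In this assay compound 4 gives > 60000 nM, a limit and not a number. Compound 1 also stands at a limit, so the size of the step between compound 1 and compound 4 cannot be read. The compounds shown leave open which structural change, if any, would yield a measurable value, as none stands apart from the others: the limit of > 60000 nM in this assay, at which 4 of the 4 values shown sit.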